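Amide variation on the trimethoxyphenyl benzylamine series

The source may hold more compounds than are shown below. What is called first, only, known or untested is meant among the compounds shown, and "the series" means these compounds.

Measured so far:
compound 1, `C=C(C)C(=O)N(Cc1ccc(OC)c(O)c1)c1cc(OC)c(OC)c(OC)c1`: 390 nM
compound 2, `COc1ccc(N(Cc2cc(OC)c(OC)c(OC)c2)C(=O)CCl)cc1O`: 24500 nM
compound 3, `COc1ccc(CNc2cc(OC)c(OC)c(OC)c2)cc1N`: 7970 nM

In a functional assay on MGC-803 cells (Homo sapiens) for inhibition, read by MTT assay, with a stated time of 48 h (on this read-out lower numbers stand for stronger inhibition and higher numbers for weaker inhibition), compound 1 gives the lowest number of the three. Compound 3 sits nearest to it, and the gap between compound 1 and compound 3 lies beyond the scatter. Compound 2 lies furthest from compound 1, again beyond the scatter. Compound 1 therefore stands alone at the strong end of the set.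

Compound 4, `COc1ccc(CN(C(=O)C(C)Br)c2cc(OC)c(OC)c(OC)c2)cc1O`, has not yet been measured. It differs from compound 1 in a single place: 1-bromoethyl in place of 1-methylethenyl on a carbonyl carbon. Within the data shown here, no pair of measured compounds differs in one place only, so there is no measured step to lean on for this change. Among the measured compounds shown here, the one other acylated compound, compound 2, shows a much weaker number than compound 1, but it differs from compound 1 in several places at once and only its value can be stated.

The step from compound 1 to compound 4 is expected to weaken inhibition beyond the scatter, a 7.7-fold higher number from compound 1 to compound 4 (0.89 log units; beyond the scatter). Compound 4 is expected to give 3000 nM, with a range of 800 nM to 12000 nM.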

Compound 4, half-maximal inhibitory concentration: 120 nM
Estimate against measurement, compound 4: 25-fold (1.40 log units) above; the measured number lies below the stated range.
By their numbers in this assay, from the lowest: compound 4; then compound 1; then compound 3; then compound 2.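

In this assay, among these compounds, the place on the carbonyl carbon proves open to change, and this is the first single-place step: 1-bromoethyl in place of 1-methylethenyl gives a 3.3-fold lower number from compound 1 to compound 4 (0.51 log units; beyond the scatter). The double bond of the 1-methylethenyl group is therefore not required for strong inhibition here, and the saturated, bromine-bearing group does modestly better. No supporting data bear on why the number falls.

Whether the bromine itself drives the step remains open, as the compounds shown include no plain ethyl or 1-chloroethyl group at this place for comparison. Also open, as far as these compounds go, is how a longer chain or an amine-bearing chain on the same carbonyl carbon would read out in this assay.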